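The compounds below may be only part of what the source reports. "The series", "measured", "known", "first", "only" and "open" are said of these compounds alone.

Compound 1 `CC(C)(C)c1ccc(CN(Cc2ccc(C(=O)NO)cc2)S(=O)(=O)c2c(F)c(F)c(F)c(F)c2F)cc1` gives 88 nM in an assay on isolated protein for inhibition of histone deacetylase 11 (Homo sapiens), read by mobility shift assay; on this read-out higher numbers stand for weaker inhibition and lower numbers for stronger inhibition. Compound 2 `O=C(NO)c1ccc(CN(Cc2ccncc2)S(=O)(=O)c2c(F)c(F)c(F)c(F)c2F)cc1` reaches only a limit of this assay, > 1000 nM. For the measured compounds named here, compound 2 therefore stands at the weak end of the two values shown, with the limit of > 1000 nM in this assay, at which 1 of the 2 values shown sits, marking its place, and the sole measured step is an at least 11-fold higher number from compound 1 to compound 2 (1.05 log units; beyond the scatter). Compound 3 `O=C(NO)c1ccc(CN(Cc2ccncc2)S(=O)(=O)c2cc(F)c(F)c(F)c2F)cc1` differs from compound 2 by hydrogen in place of fluoro on an aromatic carbon. Going by the values given here, no measured step touches that change, so no move beyond the scatter in this assay is expected. Compound 3 is estimated at 2000 nM, between 700 nM and 6000 nM, meaning a step that the limit leaves unreadable from compound 2 to compound 3, most likely again reported only as a limit.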

Compound 3, half-maximal inhibitory concentration: 472 nM
Compound 3: the middle estimate sits 4.2-fold (0.63 log units) above what was measured; the measured number lies below the stated range.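

The earlier compounds shown here changed only the group on the saturated chain carbon, whereas this change shows that the aromatic carbon ortho to a large group also counts: going from 2,3,4,5,6-pentafluorophenyl to 2,3,4,5-tetrafluorophenyl, hydrogen in place of fluoro gives an at least 2.1-fold lower number from compound 2 to compound 3 (0.32 log units; beyond the scatter) in this assay. The true size of the step stays unfixed, given where compound 2 stands: the limit of > 1000 nM in this assay, at which 1 of the 3 values shown sits. With the pyridin-4-yl group in place, losing this fluoro does not weaken inhibition. On these data alone, whether the same holds with the 4-(tert-butyl)phenyl group of compound 1 stays open. So does the effect of a chloro or methoxy group on this carbon.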